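The compounds below may be only part of what the source reports. "The series", "measured", "known", "first", "only" and "open" are said of these compounds alone.

Values so far in a functional assay on HT-29 cells (Homo sapiens) for antiproliferative activity, read by MTT assay; a higher number here means a weaker inhibitor, a lower number a stronger inhibitor
compound 1 `Oc1ccccc1/C=C/c1ccc(Br)cc1` (14400 nM)
compound 2 `Oc1ccc(/C=C/c2ccccc2O)cc1` (33500 nM)

For the measured compounds named here, compound 2 holds the higher of the two numbers, which makes it the weaker inhibitor of this pair in this assay so far. Compound 3 `Oc1ccc(/C=C/c2cc(Br)ccc2O)cc1` differs from it by one change, bromo in place of hydrogen on an aromatic carbon, para to a hydroxy group. Going by the values given here, one measured step bears on this, a modest one beyond the scatter (a 2.3-fold higher number from compound 1 to compound 2 (0.37 log units; beyond the scatter)). It gives only indirect guidance, since it exchanges bromo for hydroxy rather than hydrogen and lies at another place. Compound 1, which carries bromo, stands at 14400 nM while compound 2 stands at 33500 nM and so a similarly modest fall is expected here. The expected change is a 2.0-fold lower number from compound 2 to compound 3 (0.29 log units; within the scatter) in this estimate. Compound 3 is expected at 17000 nM with an estimated range from 7000 nM to 40000 nM in this assay once measured.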

Compound 3, half-maximal inhibitory concentration: 26700 nM
Estimate against measurement, compound 3: 1.6-fold (0.20 log units) below, and the stated range covers the measured number.
By their numbers in this assay, from the lowest: compounds 1, 3 and 2 (each within the scatter of the next, the first and the last beyond it).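

In this assay, bromo in place of hydrogen on the aromatic carbon para to a hydroxy group gives a 1.3-fold lower number from compound 2 to compound 3 (0.10 log units; within the scatter), so at this position the two compounds cannot be told apart. For the compounds shown here, this is the first direct reading of bromo against hydrogen, since the earlier step, a 2.3-fold higher number from compound 1 to compound 2 (0.37 log units; beyond the scatter), exchanged bromo for hydroxy at another place and was beyond the scatter, and the size of that step does not carry over to this position. No measurement offered here accounts for this result.

The compounds shown leave open whether a different group at this position, such as an amine, a methoxy group or a carboxylic acid, would give a number beyond the scatter. They also leave open whether bromo would do so at another place on the shared core.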